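Coumarin-bearing pyrazoline acyl group swap on HepG2 cells

A few compounds are considered here, and "the series" means these few. Any claim that something is new, unique, unknown or untested is made for them only; others in the source may bear on it.

Measured compounds:
compound 1 `CC1=NN(C(=O)CN2CCN(C)CC2)C(c2ccccc2O)C1` — "not active" (no number reported), with no number given
compound 2 `CC(=O)Oc1ccccc1C1CC(C)=NN1C(=O)CCl` — 2520 nM
compound 3 `O=C(c1ccccc1)N1N=C(c2cc3ccccc3oc2=O)CC1c1ccccc1` — 36600 nM

In a functional assay on HepG2 cells (Homo sapiens) for cytotoxicity, read by MTT assay, with a stated time of 48 h (on this read-out lower numbers stand for stronger inhibition and higher numbers for weaker inhibition), compound 2 gives 2520 nM, while compound 3 gives 36600 nM, the higher of the two numbers reported, and the gap between them lies beyond the scatter of this kind of measurement. Compound 1 gave no number at all in this assay, being reported as "not active" (no number reported). Among the compounds with values here, the three measured compounds share no single-point relation, so no measured step is available to set the size of the change that leads to compound 4 `NC(=O)C1CCN(CC(=O)N2N=C(c3cc4ccccc4oc3=O)CC2c2ccccc2)CC1`.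

Compound 4 differs from compound 3 in one place ((4-carbamoylpiperidin-1-yl)methyl in place of phenyl on a carbonyl carbon). Within the data shown here, no measured pair shows what such a change does on this core. The acyl groups of compound 2 and compound 3 are not comparable in a single step, so nothing firm can be drawn from that pair either.

Compound 4 is therefore expected to sit close to compound 3, with a small step of a 1.5-fold lower number from compound 3 to compound 4 (0.17 log units; within the scatter) in this assay that may well lie within the scatter. The estimate for compound 4 in this assay is 25000 nM, with a range from 6000 nM to 80000 nM.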

Compound 4, half-maximal inhibitory concentration: 19300 nM
Estimate against measurement, compound 4: 1.3-fold (0.11 log units) above; the range from low to high includes it.
By their numbers in this assay, from the lowest: compound 2; then compounds 4 and 3 (each within the scatter of the next).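

In this assay, within the data shown here, putting (4-carbamoylpiperidin-1-yl)methyl in place of phenyl on a carbonyl carbon gives a 1.9-fold lower number from compound 3 to compound 4 (0.28 log units; within the scatter), the first measured single-place step on this core, so the position can be read directly for the first time. The exchange is not a minor one: a six-membered aromatic ring of carbon only leaves, and a larger group enters with a non-aromatic ring, a hydrogen-bond donor and hydrogen-bond acceptors, yet the two numbers remain within the scatter of each other, which shows that at this place on the shared core the read-out does not separate these two groups. No independent measurement accounts for this result.

The compounds shown leave open whether a carboxylic acid in place of the carbamoyl group, or a longer chain in place of the methyl link to the piperidine, would also stay within the scatter of compound 3. As far as these compounds go, it also remains open whether the (4-carbamoylpiperidin-1-yl)methyl group would behave alike on the core of compound 2 , which gives 2520 nM in this assay.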